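The source may report more compounds than this note shows. Statements on the series, on what has been measured and on what is new or still open speak of the compounds shown alone.

Measured so far in a functional assay on A549 cells (Homo sapiens) for inhibition, read by MTT assay, with a stated time of 24 h; on this read-out lower numbers stand for stronger inhibition and higher numbers for weaker inhibition:
- compound 1, `CC1(C)[C@H]2CC[C@]1(C)N(Cc1cn(-c3ccccc3Br)nn1)C(=O)C2`: 130 nM
- compound 2, `CC1(C)[C@H]2CC[C@]1(C)N(Cc1cn(-c3ccc(F)cc3)nn1)C(=O)C2`: 230 nM
- compound 3, `CC1(C)[C@H]2CC[C@]1(C)N(Cc1cn(-c3ccccc3)nn1)C(=O)C2`: 70 nM

Compound 3 gives the lowest of the three numbers. Its nearest neighbour is compound 1: the step of a 1.9-fold lower number from compound 1 to compound 3 (0.27 log units; within the scatter) stays within the scatter, so the two cannot be ordered. Compound 2 stands further off, the step of a 3.3-fold lower number from compound 2 to compound 3 (0.52 log units; beyond the scatter) being a modest one beyond the scatter.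

Compound 4, `CC1(C)[C@H]2CC[C@]1(C)N(Cc1cn(-c3cccc(Br)c3)nn1)C(=O)C2`, differs from compound 3 by bromo in place of hydrogen on an aromatic carbon. Within the data shown here, the only bromo precedent is the step from compound 1 to compound 3, which removed bromo from a 2-bromophenyl and moved the number within the scatter. No 3-bromophenyl has been measured, and the fluoro step from compound 2 to compound 3 concerns a different group. On this basis the step of a 1.6-fold higher number from compound 3 to compound 4 (0.20 log units; within the scatter) is expected to stay within the scatter, with at most a slightly higher number. For compound 4 the estimate is 110 nM, with a range from 50 nM to 250 nM.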

Compound 4, half-maximal inhibitory concentration: 90 nM
Estimate against measurement, compound 4: 1.2-fold (0.09 log units) above; the range from low to high includes it.
By their numbers in this assay, from the lowest: compounds 3, 4, 1 and 2 (each within the scatter of the next, the first and the last beyond it).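

In this assay, bromo on this phenyl now has a second placement to compare: the step of a 1.3-fold higher number from compound 3 to compound 4 (0.11 log units; within the scatter) stays within the scatter, so 3-bromophenyl cannot be told apart from phenyl. Moving bromo gives no readable change either, as the step of a 1.4-fold lower number from compound 1 to compound 4 (0.16 log units; within the scatter) also stays within the scatter. The 3-bromophenyl does separate from 4-fluorophenyl, with the step of a 2.6-fold lower number from compound 2 to compound 4 (0.41 log units; beyond the scatter) a modest one beyond the scatter, so a change of aryl group at this nitrogen can still register even though the bromo steps do not.

Nothing available bears on the reason for any of these steps. As far as these compounds go, whether the gap to 4-fluorophenyl comes from the halogen or from its place stays open, as does the effect of an amine or a carboxylic acid on the phenyl.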